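Compound 3 to compound 4: methyl for methoxy

The source may report more compounds than this note shows. Statements on the series, on what has been measured and on what is new or still open speak of the compounds shown alone.

Measured in a functional assay on HeLa cells (Homo sapiens) for cytotoxicity, read by CCK-8 assay; on this read-out lower numbers stand for stronger inhibition and higher numbers for weaker inhibition:
- compound 1 `O=C(Nc1ccc(O)cc1)c1ncc(-c2ccccc2)o1` gives 780 nM as a number
- compound 2 `O=C(Nc1cccc(O)c1)c1ncc(-c2ccccc2)o1` gives > 30000 nM as a limit
- compound 3 `COc1ccc(NC(=O)c2ncc(-c3ccccc3)o2)cc1` gives > 30000 nM as a limit

Compound 3 stands at > 30000 nM in this assay and this is a limit of the assay, not a number. Its place is the limit of > 30000 nM in this assay, at which 2 of the 3 values shown sit, so it offers no number to work from.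

The change to compound 4 `Cc1ccc(NC(=O)c2ncc(-c3ccccc3)o2)cc1` is methyl in place of methoxy on an aromatic carbon para to a large group. Among the measured compounds shown here, two measured steps bear on it. Both an at least 38-fold higher number from compound 1 to compound 3 (1.58 log units; beyond the scatter) and an at least 38-fold higher number from compound 1 to compound 2 (1.58 log units; beyond the scatter) are large and beyond the scatter. Compound 4 lacks the 4-hydroxyphenyl of compound 1 just as compound 3 does, so no step beyond the scatter is expected in this assay and a report as a limit is the likeliest outcome. The expected change is a number no higher from compound 3 to compound 4 (the limit leaves the size open) as an estimate. For compound 4 the estimated value is 30000 nM (expected range 12000 nM to 60000 nM).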

Compound 4, half-maximal inhibitory concentration: > 30000 nM
Compound 4: a limit, no number; the forecaster's own chance of this, stated with the estimate: 80%; the middle value lies on the limit itself.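

In this assay compound 4 gives > 30000 nM, which is a limit of the assay and not a number. Methyl in place of hydroxy on an aromatic carbon para to a large group gives an at least 38-fold higher number from compound 1 to compound 4 (1.58 log units; beyond the scatter), so the loss seen with the methoxy of compound 3 recurs with a group that holds no oxygen, and of the compounds shown only compound 1 gives a number. The steps from compound 3 to compound 4 and from compound 2 to compound 4 cannot be read, since both ends of each are limits: the limit of > 30000 nM in this assay, at which 3 of the 4 values shown sit.

No order among compound 2, compound 3 and compound 4 can be given. From the compounds shown here alone, whether only the hydroxy gives a number at this place stays open; an amine or a carboxylic acid on the same aromatic carbon would test this.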